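This account rests on a few compounds, and the source may have more. Where it says the series, first, only, none or still open, it means among the compounds named here.

Compound 3 `CN(C(=O)CCc1cn(-c2ccc(Br)cc2)nc1-c1ccc(Cl)cc1)S(C)(=O)=O` stands at < 5000 nM in a physicochemical assay for solubility, in phosphate buffer, measured as thermodynamic solubility, at pH 7.4 (on this read-out higher numbers stand for higher solubility and lower numbers for lower solubility), and this is a limit of the assay and not a number. Its place in the series is thus (the limit of < 5000 nM in this assay, at which 1 of the 3 values shown sits).

Compound 1 `CS(=O)(=O)NC(=O)CCc1cn(-c2ccc(Cl)cc2)nc1-c1ccc(Cl)cc1` gives 100000 nM in this assay, and compound 2 `CS(=O)(=O)NC(=O)CCc1cn(-c2ccc(C(F)(F)F)cc2)nc1-c1ccc(Cl)cc1` gives 50000 nM. Going by the values given here, the one measured step, a 2.0-fold lower number from compound 1 to compound 2 (0.30 log units; within the scatter), concerns trifluoromethyl in place of chloro on an aromatic carbon, so it says little about the chain.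

Compound 4 `CS(=O)(=O)NC(=O)CCCc1cn(-c2ccc(Br)cc2)nc1-c1ccc(Cl)cc1` has the same atoms as compound 3, joined differently: ((methylsulfonyl)carbamoyl)methyl in place of methyl(methylsulfonyl)carbamoyl on a saturated chain carbon, two bonds along the chain from an aromatic carbon. Here ((methylsulfonyl)carbamoyl)methyl takes the place of methyl(methylsulfonyl)carbamoyl on a saturated chain carbon, two bonds along the chain from an aromatic carbon. Among the compounds with values here, no measured step covers this change, so the expectation rests on values alone. Compound 4 shares its unmethylated carbamoyl end with compound 1 at 100000 nM and with compound 2 at 50000 nM, though its chain differs from theirs.

A move to a higher number is therefore expected, with an estimated size of an at least 5.0-fold higher number from compound 3 to compound 4 (0.69 log units; beyond the scatter). For compound 4 the estimated value in this assay is 25000 nM, with an expected range from 6000 nM to 100000 nM.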

Compound 4, solubility: 135000 nM
Compound 4: middle estimate off by 5.4-fold (0.73 log units), on the low side; the measured number lies above the stated range.
By their numbers in this assay, from the lowest: compounds 2, 1 and 4 (each within the scatter of the next, the first and the last beyond it). At a limit, below all of these: compound 3.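

In this assay, going by these compounds alone, the earlier compounds gave only a step on an aromatic carbon, and this pair is the first to show a change at the chain end, with a large result: an at least 27-fold higher number from compound 3 to compound 4 (1.43 log units; beyond the scatter). The atoms stay the same, but ((methylsulfonyl)carbamoyl)methyl, with 1 hydrogen-bond donor, replaces methyl(methylsulfonyl)carbamoyl, with 0, on a saturated chain carbon, two bonds along the chain from an aromatic carbon, and this step lies beyond the scatter, whereas the earlier step on the aromatic carbon lies within it: a 2.0-fold lower number from compound 1 to compound 2 (0.30 log units; within the scatter). Compound 3 is held at a limit of the assay and not a number, so the step has a floor and no measured size: the limit of < 5000 nM in this assay, at which 1 of the 4 values shown sits.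

Read one bond further out, the change is (methyl(methylsulfonyl)carbamoyl)methyl to 2-((methylsulfonyl)carbamoyl)ethyl, so the amide hydrogen and the longer chain arrive together, and the compounds shown hold no pair that parts them. On these data alone, how a carboxylic acid or an amine at this chain end, or a still longer chain, would read in this assay stays open.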